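Amino for chloro on the fused core: expected loss of potency

A few compounds are considered here, and "the series" means these few. Any claim that something is new, unique, unknown or untested is made for them only; others in the source may bear on it.

Measured set:
compound 1 `ClCc1ccccc1Cn1cnc2c(Cl)nc(Cl)nc21` — 5620 nM
compound 2 `Nc1nc(Cl)c2ncn(Cc3ccc(CCl)cc3)c2n1` — 97700 nM
compound 3 `ClCc1ccccc1Cn1cnc2ncnc(Cl)c21` — 33900 nM

In a functional assay on TK-10 cells (Homo sapiens) for cytotoxicity, read by sulforhodamine B assay, with a stated time of 48 h (a higher number here means that more compound is tolerated, a lower number that less compound is tolerated), compound 1 gives 5620 nM, the lowest of the three numbers; compound 3 sits beyond the scatter above it, and compound 2 further still. Neither pair differs in only one place, so no single step can be read from the measured compounds; the two higher numbers both belong to compounds that lack the second chloro of compound 1 on the fused core.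

Compound 4 `Nc1nc(Cl)c2ncn(Cc3ccccc3CCl)c2n1` is the next compound to be measured. Relative to compound 1 the change is amino in place of chloro on an aromatic carbon. Compound 2 carries the same amino group on the same core, with the chloromethylbenzyl group attached differently, and its value in this assay is far higher than that of compound 1; compound 3, which loses that chloro without adding anything, also lies well above compound 1.

Accordingly a clear step upward in this assay is expected from compound 1 to compound 4, beyond the scatter, of about a 7.1-fold higher number from compound 1 to compound 4 (0.85 log units; beyond the scatter). Compound 4 is expected to give 40000 nM, within a range of 10000 nM to 150000 nM.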

Compound 4, concentration lethal to 50% of the cells: 75900 nM
Compound 4: the middle estimate sits 1.9-fold (0.28 log units) below what was measured; measured number inside the range.
By their numbers in this assay, from the lowest: compound 1; then compound 3; then compounds 4 and 2 (each within the scatter of the next).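

In this assay, going by these compounds alone, amino in place of chloro on the aromatic carbon between two ring nitrogen atoms gives a 14-fold higher number from compound 1 to compound 4 (1.13 log units; beyond the scatter), the first single-place step, and it shows that the low number of compound 1 depends strongly on what occupies this carbon. With amino at this carbon, compound 4 at 75900 nM and compound 2 at 97700 nM lie within the scatter of each other, so the two attachments of the chloromethyl group on the benzyl ring cannot be told apart in this pair. No available data explain the size of the step.

As far as these compounds go, whether chloro itself is the requirement or amino is specifically poor remains open; methoxy or dimethylamino at this carbon would help separate the two. Also open, from the compounds shown here alone, is how far the number depends on the chloromethyl group, which a plain methyl group in its place would test.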